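Nitro in place of methoxy on the ethoxy series

A few compounds are considered here, and "the series" means these few. Any claim that something is new, unique, unknown or untested is made for them only; others in the source may bear on it.

Of the compounds shown here, two with the shared core have been measured in a functional assay on the whole organism (strain Sprague-Dawley) for inhibition, with Rattus norvegicus as the target, with a stated time of 10 min; a lower number here means that less compound is needed, a higher number that more compound is needed for the effect. Compound 1 (`CCOc1ccc(Cl)cc1-c1ncc(C(=O)O)c(=O)[nH]1`) gives 0.5 mg/kg, and compound 2 (`CCOc1ccc(OC)cc1-c1ncc(C(=O)O)c(=O)[nH]1`) gives 0.2 mg/kg. Among the compounds with values here, compound 2 therefore holds the lower of the two numbers, and compound 1 is its only neighbour.

Compound 3 (`CCOc1ccc([N+](=O)[O-])cc1-c1ncc(C(=O)O)c(=O)[nH]1`) has nitro in place of methoxy on an aromatic carbon, para to an ethoxy group: nitro in place of methoxy on an aromatic carbon.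

Within the data shown here, only one measured step bears on this change: a 2.5-fold lower number from compound 1 to compound 2 (0.40 log units; beyond the scatter), with methoxy in place of chloro on the same carbon. It is modest but beyond the scatter, so the substituent at this carbon can move the number. Among the measured compounds shown here, no nitro compound has been measured, and the direction rests on this single pair. Since compound 2 loses the methoxy that came with a 2.5-fold lower number from compound 1 to compound 2 (0.40 log units; beyond the scatter), a modest step to a higher number is expected in this assay. The expected change is a 2.5-fold higher number from compound 2 to compound 3 (0.40 log units; beyond the scatter). For compound 3 the estimated value is 0.5 mg/kg, with an expected range of 0.15 mg/kg to 1.5 mg/kg.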

Compound 3, dose for 50% inhibition: 25 mg/kg
For compound 3 the middle estimate is 50-fold (1.70 log units) below the measured one, outside the stated range (above it).
By their numbers in this assay, from the lowest: compound 2; then compound 1; then compound 3.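

The substituent para to an ethoxy group proves far more decisive in this assay than the first pair suggested: nitro gives a 130-fold higher number from compound 2 to compound 3 (2.10 log units; beyond the scatter) and, against chloro, a 50-fold higher number from compound 1 to compound 3 (1.70 log units; beyond the scatter) in the same series. Both large steps dwarf the modest 2.5-fold lower number from compound 1 to compound 2 (0.40 log units; beyond the scatter) and place compound 3 at the high end of the three numbers, so methoxy and chloro lie relatively close together while nitro stands well apart from both. No measurement on these compounds offers an explanation for the size of this jump.

With only three groups at this carbon, the compounds shown cannot tell whether nitro is an isolated outlier or one end of a continuous trend, and an amine or a nitrile at the same carbon would help separate those two readings. As far as these compounds go, it also remains open whether the same large step would hold with a longer chain in place of the ethoxy group, since all three compounds carry that group unchanged.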